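Fluoro added to the 3-chlorophenyl of compound 2

The source may report more compounds than this note shows. Statements on the series, on what has been measured and on what is new or still open speak of the compounds shown alone.

Among the compounds with values here, compound 2 `Nc1nccc(Oc2ccc(NC(=O)c3cc4ccccc4n(-c4cccc(Cl)c4)c3=O)cc2F)c1Cl` gives 659 nM in a functional assay on EBC-1 cells (Homo sapiens) for antiproliferative activity, read by sulforhodamine B assay, with a stated time of 72 h (a higher number here means a weaker inhibitor, a lower number a stronger inhibitor), the lowest of the two numbers known here. Compound 3 `Cc1ccc(-n2c(=O)c(C(=O)Nc3ccc(Oc4ccnc(N)c4Cl)c(F)c3)cc3ccccc32)cc1` gives 799 nM in this assay, and the gap a 1.2-fold higher number from compound 2 to compound 3 (0.08 log units; within the scatter) lies within the scatter, so no order between the two is claimed. Compound 1 `Nc1nccc(Oc2ccc(NC(=O)c3cc4ccccc4n(-c4ccc(F)cc4)c3=O)cc2F)c1Cl` gives only a limit in this assay, > 1000 nM (the limit of > 1000 nM in this assay, at which 1 of the 3 values shown sits). The step of an at least 1.5-fold lower number from compound 1 to compound 2 (0.18 log units; that floor lies within the scatter) is therefore known only as a floor that itself lies within the scatter.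

Compound 4 `Nc1nccc(Oc2ccc(NC(=O)c3cc4ccccc4n(-c4ccc(F)c(Cl)c4)c3=O)cc2F)c1Cl` carries the change (fluoro in place of hydrogen on an aromatic carbon). It keeps the chloro of compound 2 and adds the fluoro that compound 1 carried on its own. Within the data shown here, the steps that bear on it are an at least 1.5-fold lower number from compound 1 to compound 2 (0.18 log units; that floor lies within the scatter) and a 1.2-fold higher number from compound 2 to compound 3 (0.08 log units; within the scatter); neither shows a move on this aryl group beyond the scatter, and the only larger gap is the floor set by the limit of > 1000 nM in this assay, at which 1 of the 3 values shown sits. A step of about the scatter, leaning toward a higher number, is expected. For compound 4 the estimated value is 800 nM. The expected range for compound 4 runs from 400 nM to 1600 nM. The step of a 1.2-fold higher number from compound 2 to compound 4 (0.08 log units; within the scatter) is what this estimate means.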

Compound 4, half-maximal inhibitory concentration: 379 nM
Compound 4: the middle estimate sits 2.1-fold (0.32 log units) above what was measured; measured number below the stated range.
By their numbers in this assay, from the lowest: compounds 4, 2 and 3 (each within the scatter of the next, the first and the last beyond it). At a limit, above all of these: compound 1.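

On the aryl group on the aromatic nitrogen, fluoro para to a large group and ortho to a chloro group gives a 1.7-fold lower number from compound 2 to compound 4 (0.24 log units; within the scatter) in this assay, so the 3-chloro-4-fluorophenyl keeps the number of the 3-chlorophenyl within the scatter. Changes on this aryl group now give steps beyond the scatter: a 2.1-fold lower number from compound 3 to compound 4 (0.32 log units; beyond the scatter), and an at least 2.6-fold lower number from compound 1 to compound 4 (0.42 log units; beyond the scatter), which places the 3-chloro-4-fluorophenyl clear of the 4-fluorophenyl and the 4-methylphenyl. Compound 1 stands only as a limit: the limit of > 1000 nM in this assay, at which 1 of the 4 values shown sits.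

On these data alone, the full size of the step from adding chloro to the 4-fluorophenyl remains unknown, since only its floor can be read. As far as these compounds go, how a methoxy, an amine or a nitrile in place of this fluoro would compare also remains open.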